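This account rests on a few compounds, and the source may have more. Where it says the series, first, only, none or still open, it means among the compounds named here.

Working notes on the series.

All three measured compounds were tested in an ADME assay on BJ cells (Homo sapiens), read by MTT assay, with a stated time of 72 h; on this read-out lower numbers stand for stronger inhibition and higher numbers for weaker inhibition. Compound 1 `Nc1nc2c(c(-c3ccco3)cn2[C@@H]2O[C@H](CO)[C@@H](O)[C@H]2O)c(=O)[nH]1` carries a furan-2-yl group on the core. In this assay compound 1 gives > 100000 nM, which is a limit of the assay and not a number. Compound 2 `Nc1nc2c(c(-c3cc4ccccc4o3)cn2[C@@H]2O[C@H](CO)[C@@H](O)[C@H]2O)c(=O)[nH]1` carries 1-benzofuran-2-yl at the same place. In this assay compound 2 gives > 100000 nM, again a limit rather than a number. The change from compound 2 to compound 1 is furan-2-yl in place of 1-benzofuran-2-yl on an aromatic carbon, and its step is a step that the two limits leave unreadable from compound 2 to compound 1; it cannot be read because of the limit of > 100000 nM in this assay, at which 2 of the 3 values shown sit.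

Compound 3 `CNc1ncnc2c1c(-c1cc3ccccc3o1)cn2[C@@H]1O[C@H](CO)[C@@H](O)[C@H]1O` has a different core; the difference between the two cores is not broken down here. In this assay, within the data shown here, compound 3 gives 75600 nM, the only number in the set. Compound 4 `CNc1ncnc2c1c(-c1ccco1)cn2[C@@H]1O[C@H](CO)[C@@H](O)[C@H]1O` is not yet measured and differs from compound 3 by furan-2-yl in place of 1-benzofuran-2-yl on an aromatic carbon, the same change as from compound 2 to compound 1.

The step from compound 3 to compound 4 is expected to be a 1.2-fold higher number from compound 3 to compound 4 (0.08 log units; within the scatter); this rests on the unreadable step that the two limits leave unreadable from compound 2 to compound 1 and on compound 3 sitting at 75600 nM. Compound 4 is therefore estimated at 90000 nM, with a range from 40000 nM to 200000 nM, and a limit report is about as likely as a number.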

Compound 4, half-maximal inhibitory concentration: 5040 nM
Compound 4: the middle estimate sits 18-fold (1.25 log units) above what was measured, and the stated range ends above it.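

In this assay, furan-2-yl in place of 1-benzofuran-2-yl gives a 15-fold lower number from compound 3 to compound 4 (1.18 log units; beyond the scatter), so on this core the change has a size that can be read. The same change on the core of compound 2 cannot be read, and neither its size nor its direction there is known, because both values of that pair are limits of the assay and not numbers: the limit of > 100000 nM in this assay, at which 2 of the 4 values shown sit. The series therefore holds a single readable pair for this change, which neither confirms nor refutes that its effect carries over from one core to the other.

The compounds shown leave open how other groups at this place on the core of compound 3 would read in this assay, for example an amine, a carboxylic acid or a phenyl group, as only furan-2-yl and 1-benzofuran-2-yl appear there. Also open, from the compounds shown here alone, is whether the step seen on this core would hold on any further core.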